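The source may hold more compounds than are shown below. What is called first, only, known or untested is meant among the compounds shown, and "the series" means these compounds.

Measured so far in an ADME assay on RAW264.7 cells (Mus musculus) for cytotoxicity, read by MTT assay, with a stated time of 48 h; a lower number here means that less compound is tolerated, a higher number that more compound is tolerated:
- compound 1 `C#CCOc1ccc(-c2noc(NC3CCCCC3)n2)cc1`: 38.3 ug/mL
- compound 2 `CC(=O)OC[C@H]1O[C@H](OC[C@@H](Cn2cc(CN(c3nc(-c4cccc(C)c4)no3)C3CCCCC3)nn2)OC(C)=O)C=C[C@@H]1OC(C)=O`: 46.4 ug/mL

Going by the values given here, only two compounds carry a number in this assay. Compound 1 gives 38.3 ug/mL and compound 2 gives 46.4 ug/mL; of the two, compound 1 sits at the smaller number, but its distance to compound 2 lies within the scatter, so nothing separates them. Among the compounds with values here, no pair differing in one place has been measured, so no step of known size exists in this assay.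

Compound 3 `C#CCOc1ccc(-c2noc(N(CC#C)C3CCCCC3)n2)cc1` is the next compound and differs from compound 1 as follows: propargyl in place of hydrogen on a nitrogen on an aromatic ring. Within the data shown here, with no comparable step available, the expectation rests only on the two numbers in hand, which sit close together. The step from compound 1 to compound 3 is expected to be small, a 1.0-fold lower number from compound 1 to compound 3 (0.00 log units; within the scatter), with no clear direction beyond the scatter. Compound 3 is therefore estimated at 38 ug/mL, within a range of 19 ug/mL to 76 ug/mL.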

Compound 3, half-maximal cytotoxic concentration: 101 ug/mL
Estimate against measurement, compound 3: 2.7-fold (0.42 log units) below, and the stated range ends below it.
By their numbers in this assay, from the lowest: compounds 1 and 2 (each within the scatter of the next); then compound 3.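

In this assay, going by these compounds alone, propargyl in place of hydrogen on a nitrogen on an aromatic ring gives a 2.6-fold higher number from compound 1 to compound 3 (0.42 log units; beyond the scatter) and so provides the first step of known size. This position, whose other neighbours are an aromatic carbon and a saturated ring carbon, is therefore not silent to substitution: in this one pair, replacing the hydrogen goes with more compound being tolerated. Nothing at hand bears on the reason for this step.

From the compounds shown here alone, whether the step is specific to propargyl remains open, since a methyl group, a longer saturated chain or a chain ending in an amine on the same nitrogen would separate the triple bond from the simple loss of the hydrogen. One pair also leaves open whether the step would recur with a different group in place of the propargyl ether on the core of compound 1.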